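A few compounds are considered here, and "the series" means these few. Any claim that something is new, unique, unknown or untested is made for them only; others in the source may bear on it.

Compound 2 `O=C1O[C@H]([C@@H](O)Cn2cc(-c3cc(F)cc(F)c3)nn2)C(OCc2ccccc2)=C1OCc1ccccc1` was tested in a functional assay on HeLa cells (Homo sapiens) for antiproliferative activity, read by MTT assay, with a stated time of 72 h (on this read-out higher numbers stand for weaker inhibition and lower numbers for stronger inhibition), where compound 2 gives 40800 nM. Compound 3 `O=C1O/C(=C\Cn2cc(-c3ccc(Br)cc3)nn2)C(OCc2ccccc2)=C1OCc1ccccc1` gives 24300 nM in this assay. Compound 1 `COc1ccc(-c2cn(C/C=C3\OC(=O)C(OCc4ccccc4)=C3OCc3ccccc3)nn2)cc1` gives only a limit of the assay, > 100000 nM. Compound 2 thus has the highest of the two numbers, and its nearest neighbour is compound 3, within the scatter.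

Compound 4 `COc1ccccc1-c1cn(C[C@H](O)[C@H]2OC(=O)C(OCc3ccccc3)=C2OCc2ccccc2)nn1` differs from compound 2 by 2-methoxyphenyl in place of 3,5-difluorophenyl on an aromatic carbon. Among the compounds with values here, the only measured step touching the same aryl group, an at least 4.1-fold lower number from compound 1 to compound 3 (0.61 log units; beyond the scatter), shows the methoxy-bearing compound with the weaker result, bounded by the limit of > 100000 nM in this assay, at which 1 of the 3 values shown sits. Compound 4 is therefore expected to change by a 1.5-fold higher number from compound 2 to compound 4 (0.17 log units; within the scatter) in this assay. Compound 4 is estimated at 60000 nM, within 25000 nM to 150000 nM.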

Compound 4, half-maximal inhibitory concentration: > 100000 nM
Compound 4 was reported as a limit; the forecaster's own chance of this, stated with the estimate: 35%; middle value at least 1.6-fold (0.22 log units) from the limit.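

On the aromatic carbon of the five-membered aromatic ring with 3 nitrogen, the aryl group also matters on the core of compound 2 in this assay, with an at least 2.4-fold higher number from compound 2 to compound 4 (0.38 log units; beyond the scatter). As with an at least 4.1-fold lower number from compound 1 to compound 3 (0.61 log units; beyond the scatter), the methoxy-bearing compound gives the weaker result, so this now holds on two different cores. The size of the new step is only a bound: the limit of > 100000 nM in this assay, at which 2 of the 4 values shown sit.

As far as these compounds go, it remains open whether the methoxy group or the loss of the fluorines accounts for the step. From the compounds shown here alone, what a plain phenyl, or an aryl group carrying an amine or a carboxylic acid, would give on this core also remains open.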